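Cyano for Piperidinylmethyl on a Melanin-Concentrating Hormone Receptor Antagonist

The source may report more compounds than this note shows. Statements on the series, on what has been measured and on what is new or still open speak of the compounds shown alone.

Measured compounds:
compound 1 `COc1ccc([C@@H](C)NC(=O)c2ccc(CC3CCN(Cc4ccc5ccccc5c4)CC3)cc2)cc1` gives 40 nM
compound 2 `CN1CCN(CCCN(c2nc3cc(F)c(F)cc3[nH]2)[C@@H]2CC[C@]3(c4cccc(CN5CCCCC5)c4)C[C@@H]3C2)CC1` gives 405 nM
compound 3 `CC(=O)N1CCN(Cc2ccc3c(c2)CC[C@H](N(C)C(=O)c2ccc(-c4ccc(F)cc4)cn2)C3)CC1` gives 300 nM

Three compounds have been run in an assay on CHO cells for antagonist activity at melanin-concentrating hormone receptor 1 (Homo sapiens), read by luminescence and calcium flux, with a stated time of 10 min; on this read-out lower numbers stand for stronger inhibition and higher numbers for weaker inhibition. Compound 2 gives the highest of the three numbers, at 405 nM. Its nearest neighbour is compound 3 at 300 nM, a gap that lies within the scatter of the method, so the two cannot be ordered. Compound 1, at 40 nM, stands a clear step away from compound 2, beyond the scatter.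

The unmeasured compound 4 `CN1CCN(CCCN(c2nc3cc(F)c(F)cc3[nH]2)[C@@H]2CC[C@]3(c4cccc(C#N)c4)C[C@@H]3C2)CC1` is derived from compound 2 by a single change: cyano in place of (piperidin-1-yl)methyl on an aromatic carbon. Among the compounds with values here, no measured pair in the set shows this change, so nothing in this assay indicates its direction or size. Compound 2 sits at the weaker end of the three and the change is confined to one substituent, so the step from compound 2 to compound 4 is expected to be small, a 1.7-fold higher number from compound 2 to compound 4 (0.24 log units; within the scatter), and may stay within the scatter. Compound 4 is therefore estimated at 700 nM, with a range from 200 nM to 2500 nM.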

Compound 4, half-maximal inhibitory concentration: 21 nM
Estimate against measurement, compound 4: 33-fold (1.52 log units) above; measured number outside the range, below it.
By their numbers in this assay, from the lowest: compounds 4 and 1 (each within the scatter of the next); then compounds 3 and 2 (each within the scatter of the next).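

In this assay, the swap of (piperidin-1-yl)methyl for cyano on this aromatic carbon, meta to a large group, gives a 19-fold lower number from compound 2 to compound 4 (1.29 log units; beyond the scatter), a large step beyond the scatter. This shows that the number is highly sensitive to the substituent at this position, and that the six-membered non-aromatic ring and its linking carbon are not required for strong inhibition on the shared core. The two groups match in hydrogen-bond donors, hydrogen-bond acceptors and net charge, and no measurement here says why the number falls.

Within the data shown here, the single pair leaves open whether the step comes from the arrival of cyano or the departure of (piperidin-1-yl)methyl. Hydrogen, chloro or aminomethyl on the same carbon would help separate the two, and the step's transfer to other cores also remains untested.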